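Swapping thiophen-3-yl for furan-3-yl in compound 3

The source may hold more compounds than are shown below. What is called first, only, known or untested is meant among the compounds shown, and "the series" means these compounds.

For the measured compounds named here, the three compounds measured so far tell one story in a functional assay on CEM-DNR-bulk cells (Homo sapiens), read by MTT assay, with a stated time of 72 h; on this read-out lower numbers stand for stronger inhibition and higher numbers for weaker inhibition. Compound 1 `Nc1nc(N)c2c(-c3cc4ccccc4o3)cn([C@@H]3O[C@H](CO)[C@@H](O)[C@H]3O)c2n1` gives > 20000 nM, which is a limit of the assay rather than a number. Compound 2 `Cc1ncnc2c1c(-c1cccs1)cn2[C@@H]1O[C@H](CO)[C@@H](O)[C@H]1O` gives > 20000 nM, again a limit. Compound 3 `CNc1ncnc2c1c(-c1ccsc1)cn2[C@@H]1O[C@H](CO)[C@@H](O)[C@H]1O` gives > 20000 nM, also a limit and not a measured value. Compound 3 therefore stands nowhere in particular among these results: every value sits at the same limit, as the limit of > 20000 nM in this assay, at which 3 of the 3 values shown sit, shows, and no compound can be placed above or below another.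

Compound 4 `CNc1ncnc2c1c(-c1ccoc1)cn2[C@@H]1O[C@H](CO)[C@@H](O)[C@H]1O` differs from compound 3 in a single place: furan-3-yl in place of thiophen-3-yl on an aromatic carbon. Going by the values given here, no two measured compounds differ in only one place, so no measured step shows how large a change of this kind can be. Because all three measured values sit at the limit described by the limit of > 20000 nM in this assay, at which 3 of the 3 values shown sit, there is no number from which a shift could be read. Compound 3 to compound 4 is expected to move in this assay by nothing beyond the scatter, and that expected step is a step that the limit leaves unreadable from compound 3 to compound 4. Compound 4 is expected to give 30000 nM, within a range from 12000 nM to 100000 nM, and most likely this assay will again report only its limit.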

Compound 4, half-maximal inhibitory concentration: > 20000 nM
Compound 4 ended at the assay's limit; the forecaster's own chance of this, stated with the estimate: 85%; the middle value lies beyond the limit too.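

No size can be read for the swap of thiophen-3-yl for furan-3-yl between compound 3 and compound 4, because neither compound gives a number, only a limit: the limit of > 20000 nM in this assay, at which 4 of the 4 values shown sit.

The compounds shown leave open whether any change to them would bring a measurable value in this assay and how large such a change would be.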